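Swapping an Aromatic Ring for Cyclohexyl on the Amine

A few compounds are considered here, and "the series" means these few. Any claim that something is new, unique, unknown or untested is made for them only; others in the source may bear on it.

Of the compounds shown here, three built on one shared core have been tested in a functional assay on MCF7 cells (Homo sapiens) for inhibition, read by sulforhodamine B assay; on this read-out higher numbers stand for weaker inhibition and lower numbers for stronger inhibition. Compound 1 `COc1cccc(NC2=CC(=O)c3c(nc4n3[C@H]3OC[C@@H](O)[C@H]3OC4)C2=O)c1` carries a 3-methoxyphenyl on the amine nitrogen, and in this assay compound 1 gives 3830 nM. Compound 2 `O=C1C(Nc2cccc(Cl)c2)=CC(=O)c2c1nc1n2[C@H]2OC[C@@H](O)[C@H]2OC1` carries a 3-chlorophenyl in that place, and compound 2 gives 2970 nM. The step of a 1.3-fold lower number from compound 1 to compound 2 (0.11 log units; within the scatter) is small. Compound 3 `CCOc1ccc(NC2=CC(=O)c3c(nc4n3[C@H]3OC[C@@H](O)[C@H]3OC4)C2=O)cc1` carries a 4-ethoxyphenyl on that nitrogen. For compound 3 the assay reports only a limit, > 4000 nM. The steps of an at least 1.0-fold higher number from compound 1 to compound 3 (0.01 log units; that floor lies within the scatter) and an at least 1.3-fold higher number from compound 2 to compound 3 (0.12 log units; that floor lies within the scatter) both have floors within the scatter, so compound 3 cannot be told apart from compound 1 or compound 2 by these measurements.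

Compound 4 `O=C1C(NC2CCCCC2)=CC(=O)c2c1nc1n2[C@H]2OC[C@@H](O)[C@H]2OC1` is the next compound to be measured and differs from compound 3 in one place: cyclohexyl in place of 4-ethoxyphenyl on an amine nitrogen. Among the measured compounds shown here, every step measured so far exchanges one aromatic group on that nitrogen for another, and none of them moves beyond the scatter; no measured step replaces the aromatic ring with a saturated one. A step that the limit leaves unreadable from compound 3 to compound 4 is therefore expected, meaning no change beyond the scatter. Compound 4 is thus estimated at 5000 nM, with a range from 2500 nM to 10000 nM, and a fair chance that the assay again reports only a limit.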

Compound 4, half-maximal inhibitory concentration: > 16000 nM
Compound 4 gave a limit, no number; the forecaster's own chance of this, stated with the estimate: 55%; middle value at least 3.2-fold (0.50 log units) from the limit.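

Cyclohexyl in place of an aromatic ring on the amine nitrogen gives the first steps at this position that go beyond the scatter in this assay, with an at least 5.3-fold higher number from compound 2 to compound 4 (0.73 log units; beyond the scatter) and an at least 4.1-fold higher number from compound 1 to compound 4 (0.62 log units; beyond the scatter). These sizes are only floors, and the true steps may be larger, as the reading for compound 4 is a limit and not a number: the limit of > 16000 nM in this assay, at which 1 of the 4 values shown sits.

The step between compound 3 and compound 4 cannot be read, as the reading for compound 3 is also only a limit: the limit of > 4000 nM in this assay, at which 1 of the 4 values shown sits.

The compounds shown therefore tie the loss to the saturated ring only in comparison with the 3-methoxyphenyl of compound 1 and the 3-chlorophenyl of compound 2, and they leave open whether another non-aromatic group on this nitrogen, such as cyclopentyl, a piperidine ring or an open hexyl chain, would read like cyclohexyl. They also leave open whether a benzyl group, which keeps an aromatic ring but sets it one carbon further from the nitrogen, would stay in the range of compound 1 and compound 2.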